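Three Amides at the Cytotoxicity Limit, a Fourth Expected There

The source may report more compounds than this note shows. Statements on the series, on what has been measured and on what is new or still open speak of the compounds shown alone.

Compound 1 `CCCCNc1nccnc1C(=O)NCc1ccccc1`: > 100000 nM, a limit of the test, not a number.
Compound 2 `CCCCCCNc1nccnc1C(=O)NCc1ccccc1`: > 100000 nM, a limit of the test, not a number.
Compound 3 `CCCCCCCNc1cncc(C(=O)NCc2ccccc2)n1`: > 100000 nM, a limit of the test, not a number.

All three values come from an ADME assay on HeLa cells (Homo sapiens) for cytotoxicity, read by microscopy, with a stated time of 6 days; on this read-out higher numbers stand for lower toxicity in this test and lower numbers for higher toxicity in this test. The step that the two limits leave unreadable from compound 2 to compound 1 is the change (hydrogen in place of ethyl on a saturated chain carbon, four bonds along the chain from a nitrogen on an aromatic ring); both ends sit at a limit, so its size cannot be read, as the limit of > 100000 nM in this assay, at which 3 of the 3 values shown sit, states. Compound 3 stands only as a limit in this assay , like the two others. How the core of compound 3 differs from the core of compound 2 is not broken down here. Compound 4 `CCCCCNc1cncc(C(=O)NCc2ccccc2)n1` differs from compound 3 by hydrogen in place of ethyl on a saturated chain carbon, five bonds along the chain from a nitrogen on an aromatic ring, the same kind of change as from compound 2 to compound 1, though the place line differs: five bonds along the chain rather than four. In this assay the step that the limit leaves unreadable from compound 3 to compound 4 is expected to be unreadable in the same way, resting on compound 3 giving > 100000 nM and on (the limit of > 100000 nM in this assay, at which 3 of the 3 values shown sit). Compound 4 is estimated at 150000 nM in this assay , expected between 60000 nM and 400000 nM.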

Compound 4, minimum cytotoxic concentration: > 100000 nM
Compound 4 gave a limit, no number (the forecaster's own chance of this, stated with the estimate: 85%); the middle value is on the limit's open side.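

Compound 3 and compound 4 both rest at a limit of the test, so no new step can be read between them in this assay: the limit of > 100000 nM in this assay, at which 4 of the 4 values shown sit.

The compounds shown leave open at what concentration, if any, either chain length would become toxic to these cells.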